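The source may report more compounds than this note shows. Statements on the series, on what has been measured and on what is new or still open speak of the compounds shown alone.

Measured compounds:
compound 1 `Cc1cc(=O)n(-c2ccc(F)cc2)nc1C(=O)Nc1ccc(Oc2ncnc3[nH]ccc23)c(F)c1` — 12900 nM
compound 2 `Cc1cc(=O)n(-c2cccc(F)c2)nc1C(=O)Nc1ccc(Oc2ncnc3[nH]ccc23)c(F)c1` — 23100 nM
compound 3 `Cc1cc(=O)n(-c2ccc(Br)cc2F)nc1C(=O)Nc1ccc(Oc2ncnc3[nH]ccc23)c(F)c1` — 32000 nM

In a functional assay on HepG2 cells (Homo sapiens) for cytotoxicity, read by MTT assay, with a stated time of 72 h (on this read-out higher numbers stand for weaker inhibition and lower numbers for stronger inhibition), compound 3 gives the highest of the three numbers. The step of a 1.4-fold higher number from compound 2 to compound 3 (0.14 log units; within the scatter) stays within the scatter, while the step of a 2.5-fold higher number from compound 1 to compound 3 (0.39 log units; beyond the scatter) lies beyond it. Compound 4 `Cc1cc(=O)n(-c2cccc(C(F)(F)F)c2)nc1C(=O)Nc1ccc(Oc2ncnc3[nH]ccc23)c(F)c1` differs from compound 3 by 3-(trifluoromethyl)phenyl in place of 4-bromo-2-fluorophenyl on an aromatic nitrogen. Among the measured compounds shown here, the only guidance comes from earlier exchanges of the group on the aromatic nitrogen: a 1.8-fold higher number from compound 1 to compound 2 (0.25 log units; within the scatter) and a 1.4-fold higher number from compound 2 to compound 3 (0.14 log units; within the scatter) both stay within the scatter, and a 2.5-fold higher number from compound 1 to compound 3 (0.39 log units; beyond the scatter) is only modest. Compound 4 is therefore expected to lie near compound 3, and the step of a 1.3-fold lower number from compound 3 to compound 4 (0.11 log units; within the scatter) is estimated to remain within the scatter. The estimate for compound 4 in this assay is 25000 nM, with a range from 10000 nM to 60000 nM.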

Compound 4, half-maximal inhibitory concentration: 26300 nM
Estimate against measurement, compound 4: 1.1-fold (0.02 log units) below; the range from low to high includes it.
By their numbers in this assay, from the lowest: compounds 1, 2, 4 and 3 (each within the scatter of the next, the first and the last beyond it).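

In this assay, the exchange of trifluoromethyl for fluoro on an aromatic carbon barely registers: a 1.1-fold higher number from compound 2 to compound 4 (0.06 log units; within the scatter). Changing the whole group on the aromatic nitrogen gives a 1.2-fold lower number from compound 3 to compound 4 (0.09 log units; within the scatter), while only a 2.0-fold higher number from compound 1 to compound 4 (0.31 log units; beyond the scatter) passes the scatter, and modestly. No measurement shown accounts for this flat response. From the compounds shown here alone, all four groups are fluorinated phenyl rings, so it remains open whether an amine or a carboxylic acid on that ring, or a simple alkyl chain replacing it, would shift the number further.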